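Adding a Second Chloro Group on a Changed Core

The compounds below may be only part of what the source reports. "The series", "measured", "known", "first", "only" and "open" are said of these compounds alone.

Compound 1 `ClCc1cccc(Cn2cnc3c(Cl)ncnc32)c1` and compound 2 `ClCc1cccc(Cn2cnc3c(Cl)nc(Cl)nc32)c1` share one core; compound 3 `ClCc1ccccc1Cn1cnc2ncnc(Cl)c21` has the same atoms joined differently, and the difference between the two cores is not broken down here. In a functional assay on HCC 2998 cells (Homo sapiens) for cytotoxicity, read by sulforhodamine B assay, with a stated time of 48 h (a lower number here means a stronger inhibitor of growth, a higher number a weaker inhibitor of growth), compound 1 gives 1730 nM, compound 2 gives 3160 nM, and compound 3 gives 4260 nM. The change from compound 1 to compound 2 is chloro in place of hydrogen on an aromatic carbon, and it made a step of a 1.8-fold higher number from compound 1 to compound 2 (0.26 log units; within the scatter). Compound 4 `ClCc1ccccc1Cn1cnc2nc(Cl)nc(Cl)c21` carries the same change on the core of compound 3, namely (chloro in place of hydrogen on an aromatic carbon). Among the measured compounds shown here, since the one measured example of this change gave a 1.8-fold higher number from compound 1 to compound 2 (0.26 log units; within the scatter), a step of similar size is expected here, giving a 1.8-fold higher number from compound 3 to compound 4 (0.25 log units; within the scatter). Compound 4 is therefore estimated at 7600 nM in this assay, with a likely range from 3500 nM to 16000 nM.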

Compound 4, concentration for total growth inhibition: 35500 nM
The estimate for compound 4 lay 4.7-fold (0.67 log units) below the measured number; the whole stated range lies below it.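

Placing chloro on the aromatic carbon between two ring nitrogen atoms of the core of compound 3 gave an 8.3-fold higher number from compound 3 to compound 4 (0.92 log units; beyond the scatter) in this assay. The same change therefore did not carry over at the same size from one core to the other: the same change on two cores in this assay, a 1.8-fold higher number (0.26 log units; within the scatter) from compound 1 to compound 2 and an 8.3-fold higher number (0.92 log units; beyond the scatter) from compound 3 to compound 4, 4.6-fold (0.66 log units) apart, beyond the scatter of two such steps. This shows that a step measured on one core can be a poor guide to its size on the other, but it does not show why the cores differ, and two pairs of compounds make no rule for the series.

From the compounds shown here alone, whether another group at this position, such as an amine or a methoxy group, would also give steps that differ between the two cores remains open. So does whether the same gap would appear on other cell lines.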